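The source may hold more compounds than are shown below. What is called first, only, known or untested is meant among the compounds shown, and "the series" means these compounds.

Working notes on the series. Compound 1 is `CN(C)c1nc(N)nc2c1ncn2/C=C1/CC1(CO)CO` and has been measured in an ADME assay on HFF cells (Homo sapiens) for cytotoxicity, with a stated time of 8 days; on this read-out higher numbers stand for lower toxicity in this test and lower numbers for higher toxicity in this test. In this assay compound 1 gives > 300000 nM, which is a limit of the assay and not a number. Compound 2 is `CCCNc1nc(N)nc2c1ncn2/C=C1/CC1(CO)CO`, with propylamino in place of dimethylamino on an aromatic carbon. In this assay compound 2 gives > 300000 nM, again a limit. Compound 3 is `CC(C)Sc1nc(N)nc2c1ncn2/C=C1/CC1(CO)CO`, with isopropylsulfanyl in place of dimethylamino on an aromatic carbon. In this assay compound 3 gives > 300000 nM, also a limit. None of the steps among these three can be sized: a step that the two limits leave unreadable from compound 1 to compound 2, a step that the two limits leave unreadable from compound 1 to compound 3 and a step that the two limits leave unreadable from compound 2 to compound 3 each run between two limits, since every value so far rests at the limit of > 300000 nM in this assay, at which 3 of the 3 values shown sit.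

Compound 4 is `CCCCCCOc1nc(N)nc2c1ncn2/C=C1/CC1(CO)CO`. It differs from compound 1 in one place: hexyloxy in place of dimethylamino on an aromatic carbon. Among the compounds with values here, the steps that bear on this change are those from compound 1 to compound 2 and from compound 1 to compound 3, which likewise replace dimethylamino by another group on an aromatic carbon, and neither has a readable size or direction. No step beyond the scatter is therefore expected in this assay, and a limit is the most likely report. Compound 4 is expected to give 300000 nM, between 100000 nM and 1000000 nM, in this assay. The estimated step is a number no higher from compound 1 to compound 4 (the limit leaves the size open).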

Compound 4, half-maximal cytotoxic concentration: > 200000 nM
Compound 4 was reported as a limit; the forecaster's own chance of this, stated with the estimate: 80%; the middle value is on the limit's open side.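

Within the data shown here, compound 4 reads as a limit of this assay, as do compound 1, compound 2 and compound 3, so no step from any of these three to compound 4 can be read. The compounds shown leave open what the true half-maximal cytotoxic concentrations of all four are, and whether exchanging these groups on the shared core changes them at all.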